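Fluorine on the Outer Phenyl: Expected Cytotoxicity of Compound 4

The source may report more compounds than this note shows. Statements on the series, on what has been measured and on what is new or still open speak of the compounds shown alone.

Measured compounds:
Compound 1 `O=c1[nH]cc(S(=O)(=O)Nc2ccccc2-c2cn(-c3ccc(F)cc3)nn2)c(=O)[nH]1`, "not toxic" (no number reported)
Compound 2 `Cc1ccc(-n2cc(-c3cccc(NS(=O)(=O)c4c[nH]c(=O)[nH]c4=O)c3)nn2)cc1`, 15800 nM
Compound 3 `O=c1[nH]cc(S(=O)(=O)Nc2ccc(-c3cn(-c4ccccc4)nn3)cc2)c(=O)[nH]1`, "not toxic" (no number reported)

In an ADME assay on GES1 cells (Homo sapiens) for cytotoxicity, read by MTT assay, with a stated time of 24 h (a higher number here means that more compound is tolerated, a lower number that less compound is tolerated), compound 3 gives "not toxic" (no number reported), so no single number describes where it stands. Compound 1 is in the same position, with "not toxic" (no number reported) in this assay. Only compound 2 carries a number, 15800 nM in this assay. Within the data shown here, no step between two measured compounds differing in one place is available, so the size of a single change cannot be read from these data.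

Compound 4 `O=c1[nH]cc(S(=O)(=O)Nc2ccc(-c3cn(-c4ccc(F)cc4)nn3)cc2)c(=O)[nH]1` is the compound still to be measured. It differs from compound 3 by fluoro in place of hydrogen on an aromatic carbon, the same change that reads as phenyl to 4-fluorophenyl one bond further out. For this step in this assay no effect beyond the usual scatter is expected, in either direction. Compound 1, which also bears a 4-fluorophenyl on the same kind of position, returned "not toxic" (no number reported), and this supports the expectation that compound 4 will tolerate a large amount of compound. For compound 4 an estimated value of 40000 nM in this assay, in the range 15000 nM to 120000 nM, is expected, with a good chance that the assay again reports no single number.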

Compound 4, half-maximal cytotoxic concentration: > 100000 nM
Compound 4 gave a limit, no number (the forecaster's own chance of this, stated with the estimate: 65%); at least 2.5-fold (0.39 log units) between middle value and limit.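

Compound 4 gives > 100000 nM, which is a limit and not a number. Compound 3 has no single number, so no step can be read between compound 3 and compound 4. The compounds shown leave open what size, if any, the change from phenyl to 4-fluorophenyl has in this assay.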